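Swapping the Benzyl Halogen in a Pyridylmethylamine Series

The compounds below may be only part of what the source reports. "The series", "measured", "known", "first", "only" and "open" are said of these compounds alone.

Compound 1 `COc1cc(CNCc2ccncc2)ccc1OCc1cccc(F)c1` is one of two measured members of a small series built on a shared core. In a functional assay on HeLa cells (Homo sapiens) for inhibition, with a stated time of 72 h (on this read-out lower numbers stand for an effect already at smaller amounts and higher numbers for an effect only at larger amounts of compound), compound 1 gives 4800 nM. The other measured member, compound 2 `CCOc1cc(CNCc2ccncc2)ccc1OCc1ccc(Cl)cc1`, differs from compound 1 in two places at once, and in this assay compound 2 gives 2500 nM. The gap between these two values lies within the usual scatter of repeated measurements, so the data cannot separate them, and neither can be called more or less potent than the other.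

The step followed here leads from compound 1 to compound 3 `COc1cc(CNCc2ccncc2)ccc1OCc1ccc(Cl)cc1`, which has not yet been measured in this assay. The change is a single one: 4-chlorophenyl in place of 3-fluorophenyl on a saturated chain carbon bound to an oxygen on an aromatic ring. Compound 3 shares its 4-chlorobenzyl group with compound 2, but keeps the remaining part of compound 1 unchanged.

Among the measured compounds shown here, with no measured pair differing in only this one place, the expectation for this assay rests on the two values shown. Because compound 2 gives 2500 nM with the same entering group, the step from compound 1 to compound 3 is expected to be small, at most a modest move toward lower numbers, and likely within the scatter, as a 1.5-fold lower number from compound 1 to compound 3 (0.18 log units; within the scatter). For compound 3 the estimated value is 3200 nM, with a plausible range from 1300 nM to 8000 nM.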

Compound 3, half-maximal effective concentration: 890 nM
Compound 3: middle estimate off by 3.6-fold (0.56 log units), on the high side; measured number below the stated range.
By their numbers in this assay, from the lowest: compound 3; then compounds 2 and 1 (each within the scatter of the next).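

In this assay, the change from 3-fluorobenzyl to 4-chlorobenzyl can now be read on its own, and it gives a 5.4-fold lower number from compound 1 to compound 3 (0.73 log units; beyond the scatter), a step beyond the scatter that the earlier pair could not show, as those two compounds differ in two places at once. The second new pair isolates the other place, with hydrogen in place of methyl on a saturated chain carbon bound to an oxygen on an aromatic ring, and it gives a 2.8-fold lower number from compound 2 to compound 3 (0.45 log units; beyond the scatter), also beyond the scatter. Both places therefore affect the number in this series, and the lack of a separation in the earlier pair said nothing about either change alone.

The compounds shown leave open whether the step from 3-fluorobenzyl to 4-chlorobenzyl follows the halogen or its place on the ring: these two groups differ in both, and a 4-fluorophenyl or a 3-chlorophenyl group would pull the two apart. Nothing measured here accounts for the size of either step.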